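The compounds below may be only part of what the source reports. "The series", "measured", "known", "first", "only" and "open" are said of these compounds alone.

Compound 1 `CCCCCCCO[C@@H]1[C@@H](OCc2ccccc2)[C@@H](OCc2ccccc2)O[C@H](C=O)[C@H]1OCc1ccc(OC)cc1` gives 4 ug/mL in a functional assay on MCF7 cells (Homo sapiens) for cytotoxicity, in the presence of a further agent that is not named here (on this read-out lower numbers stand for an effect already at smaller amounts and higher numbers for an effect only at larger amounts of compound), as a real number. Compound 2 `CCCCCCCO[C@@H]1[C@@H](OCc2ccccc2)[C@@H](OCc2ccccc2)O[C@H](C=C(C)C)[C@H]1OCc1ccc(OC)cc1` stands at > 20 ug/mL and this is a limit. Compound 3 `CCCCCCCO[C@@H]1[C@@H](OCc2ccccc2)[C@@H](OCc2ccccc2)O[C@H](CC(C)C)[C@H]1OCc1ccc(OC)cc1` also rests on the limit of > 20 ug/mL in this assay, at which 2 of the 3 values shown sit, with its > 20 ug/mL being a limit and not a number. Compound 4 `CCCCCCCO[C@@H]1[C@@H](OCc2ccccc2)[C@@H](OCc2ccccc2)O[C@H](CC(C)C)[C@H]1OC` differs from compound 3 by hydrogen in place of 4-methoxyphenyl on a saturated chain carbon bound to an oxygen on a saturated carbon and the change reads as (4-methoxybenzyl)oxy to methoxy. The steps of an at least 5.0-fold higher number from compound 1 to compound 2 (0.69 log units; beyond the scatter) and an at least 5.0-fold higher number from compound 1 to compound 3 (0.69 log units; beyond the scatter) both replace formyl and leave this place untouched, and a step that the two limits leave unreadable from compound 2 to compound 3 adds nothing. Going by the values given here, no measured step therefore bears directly on the change. The expected outcome in this assay is a step that the limit leaves unreadable from compound 3 to compound 4 and no expected move beyond the scatter in either direction. For compound 4 the estimate is 25 ug/mL with an expected range from 8 ug/mL to 60 ug/mL in all.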

Compound 4, half-maximal effective concentration: > 20 ug/mL
Compound 4: a limit, no number (the forecaster's own chance of this, stated with the estimate: 65%); the middle value does not contradict the limit.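

No step can be read between compound 3 and compound 4, since both rest on the same limit: the limit of > 20 ug/mL in this assay, at which 3 of the 4 values shown sit.

Still open, going by these compounds, is what the change from (4-methoxybenzyl)oxy to methoxy does in a compound with a measurable number, such as compound 1.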